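The source may hold more compounds than are shown below. What is called first, only, known or untested is meant among the compounds shown, and "the series" means these compounds.

Compound 1, `Cc1cc(C)c(S(=O)(=O)N2CCC(C3OCC(C)CO3)CC2)c(C)c1`, is the starting point of this account. In a functional assay on DLD-1 cells (Homo sapiens) for antiproliferative activity, read by CellTiter-Glo, with a stated time of 72 h (a higher number here means a weaker inhibitor, a lower number a stronger inhibitor), compound 1 gives only a limit, > 5000 nM, and no number. This is the upper boundary of the measurement, as noted in the limit of > 5000 nM in this assay, at which 1 of the 2 values shown sits. Compound 2, `Cc1cccc(S(=O)(=O)N2CCC(N3CCC(C)CC3)CC2)c1`, shares the sulfonylpiperidine core and carries a saturated amine ring on that core. In this assay compound 2 gives 25 nM.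

Compound 3, `Cc1cc(C)c(S(=O)(=O)N2CCC(N3CCC(C(C)C)CC3)CC2)c(C)c1`, differs from compound 1 in a single place: a group of 9 heavy atoms (8 carbon, 1 nitrogen; one six-membered non-aromatic ring with 1 hetero atom) in place of a group of 7 heavy atoms (5 carbon, 2 oxygen; one six-membered non-aromatic ring with 2 hetero atoms), on a saturated ring carbon. The group that enters, the 4-isopropylpiperidin-1-yl group, resembles the amine-bearing ring of compound 2, which sits far from the limit where compound 1 sits.

For the measured compounds named here, no measured pair shows this exact exchange, so the size of the step is read from the two compounds themselves. Given that compound 2 gives 25 nM, a gain well beyond the usual scatter is expected, and the estimated step is an at least 100-fold lower number from compound 1 to compound 3 (2.00 log units; beyond the scatter). Compound 3 is expected to give about 50 nM, within a range from 10 nM to 400 nM, in this assay.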

Compound 3, half-maximal inhibitory concentration: 0.3 nM
Compound 3: middle estimate off by 170-fold (2.22 log units), on the high side; the measured number lies below the stated range.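

In this assay, for the compounds shown here, the earlier compounds could not isolate this change, since compound 1 and compound 2 differ in more than one place; compound 3 shows that one exchange alone, on a saturated ring carbon of the shared core, separates a compound with no measured number from one with a sub-nanomolar value. Compound 1 gives > 5000 nM as a limit and not a number. Placing the 4-isopropylpiperidin-1-yl group on that carbon, in place of the ring with 2 hetero atoms, gives an at least 16000-fold lower number from compound 1 to compound 3 (4.22 log units; beyond the scatter) and the true size of this step stays unknown, because the value for compound 1 is bounded on one side only: the limit of > 5000 nM in this assay, at which 1 of the 3 values shown sits.

The compounds shown leave open which part of the entering group carries this gain, since the ring nitrogen and the isopropyl group arrive together. As far as these compounds go, how a cyclohexyl group, with a carbon in place of that nitrogen, or a morpholin-4-yl group would fare at this place on the core of compound 3 also remains open.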